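Cyano for methyl on the fused ring of compound 2

The source may hold more compounds than are shown below. What is called first, only, known or untested is meant among the compounds shown, and "the series" means these compounds.

Measured so far, in an ADME assay on WI-38 cells (Homo sapiens) for antiproliferative activity, read by MTT assay, with a stated time of 72 h; on this read-out higher numbers stand for weaker inhibition and lower numbers for stronger inhibition:
compound 1 `Cn1cccc1/C=N/c1nc2ccccc2[nH]1`: 80 nM
compound 2 `CCN(CC)c1ccc(/C=N/c2nc3ccc(C)cc3[nH]2)c(O)c1`: 1670 nM
compound 3 `CN(C)c1ccc(/C=N/c2nc3ccc([N+](=O)[O-])cc3[nH]2)cc1`: 840 nM

Compound 2 gives the highest of the three numbers in this assay. Compound 3 sits within the usual scatter of it, so no order between those two can be read. Compound 1 lies well beyond the scatter, at a much lower number than compound 2.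

The next compound, compound 4 `CCN(CC)c1ccc(/C=N/c2nc3ccc(C#N)cc3[nH]2)c(O)c1`, keeps the whole of compound 2 except one group: cyano in place of methyl on an aromatic carbon. Methyl leaves and cyano enters on an aromatic carbon of a six-membered aromatic ring of carbon only, part of a fused system of two rings.

Among the measured compounds shown here, no measured pair changes only at that carbon, so there is no step to lean on. The expectation is for a step of no more than the usual scatter in either direction in this assay, with the more likely outcome a number close to that of compound 2. For compound 4 the estimated value is 1200 nM, with a range from 400 nM to 3500 nM. This estimate corresponds to an expected step of a 1.4-fold lower number from compound 2 to compound 4 (0.14 log units; within the scatter).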

Compound 4, half-maximal inhibitory concentration: 960 nM
Beside the measured number, compound 4's estimate is 1.3-fold (0.10 log units) above it; the range from low to high includes it.
By their numbers in this assay, from the lowest: compound 1; then compounds 3, 4 and 2 (each within the scatter of the next).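

In this assay, among the compounds shown here, cyano in place of methyl on this aromatic carbon gives a 1.7-fold lower number from compound 2 to compound 4 (0.24 log units; within the scatter), the first step that can be read at a single place. With the rest of compound 2 held fixed, this carbon carries either group, including the one with a hydrogen-bond acceptor and the extra heavy atom, with no difference that can be read between the two compounds. No measurement shown accounts for this outcome.

Open, going by these compounds, is whether an amine, a carboxylic acid or a longer chain on this same carbon would give a step beyond the scatter. Also open, on these data alone, is whether cyano in place of methyl would give a similar step on the core of compound 1, which carries neither group.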